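The source may report more compounds than this note shows. Statements on the series, on what has been measured and on what is new or still open speak of the compounds shown alone.

Measured in a functional assay on HaCaT cells (Homo sapiens) for antiproliferative activity, read by sulforhodamine B assay, with a stated time of 3 days; a higher number here means a weaker inhibitor, a lower number a stronger inhibitor:
Compound 1 `COC(=O)c1cc(CCc2cccc(OC)c2)ccc1O`: 37000 nM
Compound 2 `CCOc1ccc(OC)cc1CCc1ccc(O)c(C(=O)OC)c1`: 120 nM

Compound 2 has the lower of the two numbers, which makes it the stronger inhibitor of this pair. Compound 3 `CCOc1ccc(OCC)c(CCc2ccc(O)c(C(=O)OC)c2)c1` has not yet been measured. It differs from compound 2 by methyl in place of hydrogen on a saturated chain carbon bound to an oxygen on an aromatic ring, so a methoxy becomes an ethoxy.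

Going by the values given here, only one measured step offers guidance, and it is large: a 310-fold lower number from compound 1 to compound 2 (2.49 log units; beyond the scatter), with ethoxy in place of hydrogen on an aromatic carbon. That was a different change, however, and it gives no direct measure of this one. The new change is smaller, so no step beyond the scatter is expected in this assay. The expected result is a 1.3-fold higher number from compound 2 to compound 3 (0.10 log units; within the scatter). For compound 3 the estimate is 150 nM, with an expected range of 40 nM to 600 nM.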

Compound 3, half-maximal inhibitory concentration: 380 nM
Compound 3: middle estimate off by 2.5-fold (0.40 log units), on the low side, within the range that was stated.
By their numbers in this assay, from the lowest: compound 2; then compound 3; then compound 1.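

In this assay, the change of a methoxy to an ethoxy, with methyl in place of hydrogen on a saturated chain carbon bound to an oxygen on an aromatic ring, gives a 3.2-fold higher number from compound 2 to compound 3 (0.50 log units; beyond the scatter). The earlier step showed only that adding an ethoxy to an aromatic carbon can lower the number greatly; this step shows that one extra methyl on an existing methoxy is enough to move the number beyond the scatter, and in the opposite direction, toward a weaker inhibitor. Nothing measured here explains this shift.

Going by these compounds, it remains open whether a longer chain at this place, such as propoxy or butoxy, would raise the number further. A branched isopropoxy or a hydroxy in place of the ethoxy is equally untested by the compounds shown.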